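Aminoquinone series on the shared core: compound 1 to compound 4

The source may report more compounds than this note shows. Statements on the series, on what has been measured and on what is new or still open speak of the compounds shown alone.

Measured compounds:
compound 1, `O=C1C=C(NCc2ccccc2)C(=O)c2c1nc1n2[C@H]2OC[C@@H](O)[C@H]2OC1`, > 8000 nM in a functional assay on ECa-109 cells for inhibition, with ECa-109 cell line (Homo sapiens) as the target, read by sulforhodamine B assay; a lower number here means a stronger inhibitor, a higher number a weaker inhibitor
compound 2, `O=C1C(Nc2ccc(Br)cc2)=CC(=O)c2c1nc1n2[C@H]2OC[C@@H](O)[C@H]2OC1`, 1980 nM
compound 3, `COc1ccc(NC2=CC(=O)c3c(nc4n3[C@H]3OC[C@@H](O)[C@H]3OC4)C2=O)cc1`, 3410 nM

For the measured compounds named here, compound 1 stands at the limit of the assay: its value, > 8000 nM, is a limit and not a number, and compound 1 is the one compound of the three that sits there (the limit of > 8000 nM in this assay, at which 1 of the 3 values shown sits). Going by the values given here, compounds 2 and 3 carry an arylamino group on the shared core and give numbers; the one step among them, a 1.7-fold higher number from compound 2 to compound 3 (0.24 log units; within the scatter), changes little.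

The unmeasured compound is compound 4, `O=C1C=C(N2CCCCC2)C(=O)c2c1nc1n2[C@H]2OC[C@@H](O)[C@H]2OC1`. It differs from compound 1 by piperidin-1-yl in place of benzylamino on a double-bonded ring carbon. Among the compounds with values here, no measured step covers this kind of change: the only step in hand swaps one substituent on an aromatic ring for another, while here the benzylamino group itself is replaced. Within the data shown here, the measured values place the benzylamino compound 1 weaker than the two arylamino compounds, which are the only numbers to anchor an expectation.

Compound 4 is expected to stay weak, with an estimated 9000 nM and a range from 3000 nM to 30000 nM, and a fair chance that the assay again reports only a limit. The step this estimate implies is expected to be a step that the limit leaves unreadable from compound 1 to compound 4.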

Compound 4, half-maximal inhibitory concentration: > 8000 nM
Compound 4 gave a limit, no number; the forecaster's own chance of this, stated with the estimate: 50%; the middle value does not contradict the limit.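

The value of compound 4 in this assay is a limit and not a number: > 8000 nM. Compound 1 also sits at a limit, so no step can be read between compound 1 and compound 4: the limit of > 8000 nM in this assay, at which 2 of the 4 values shown sit. The compounds shown leave open whether piperidin-1-yl or benzylamino gives the stronger inhibitor on the shared core.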